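Adding chloro to compound 3: an expectation

The source may report more compounds than this note shows. Statements on the series, on what has been measured and on what is new or still open speak of the compounds shown alone.

Compound 3 `CC1(C)C(=O)Nc2nc(-n3nc(CCC(F)(F)F)c4ccccc43)nc(N)c21` gives the highest number of the three compounds measured; in an assay on CHO cells for activation of soluble guanylate cyclase alpha1/beta1 complex (Homo sapiens), read by cGMP accumulation (on this read-out lower numbers stand for an effect already at smaller amounts and higher numbers for an effect only at larger amounts of compound), compound 3 gives 882000 nM. Going by the values given here, compound 1 `CCCc1nn(-c2nc(N)c3c(n2)NC(=O)C3(C)C)c2ccc(Cl)cc12` gives 546000 nM, within the scatter of compound 3, while compound 2 `CCCCc1nn(-c2nc(N)c3c(n2)NC(=O)C3(C)C)c2ccc(Cl)cc12` gives 47000 nM, and the step of a 12-fold lower number from compound 1 to compound 2 (1.07 log units; beyond the scatter) is the only single-point change measured. Compound 4 `CC1(C)C(=O)Nc2nc(-n3nc(CCC(F)(F)F)c4cc(Cl)ccc43)nc(N)c21` differs from compound 3 by chloro in place of hydrogen on an aromatic carbon. Among the compounds with values here, no measured pair isolates that change: compounds 1 and 2 carry the chloro but also differ from compound 3 in the chain, so the step from compound 1 to compound 2 does not bear on it. Compound 4 is therefore expected to show a step of a 1.5-fold lower number from compound 3 to compound 4 (0.17 log units; within the scatter), not beyond the scatter. Compound 4 is estimated at 600000 nM, in the range 200000 nM to 2000000 nM.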

Compound 4, half-maximal effective concentration: 87000 nM
Compound 4: the middle estimate sits 6.9-fold (0.84 log units) above what was measured, and the stated range ends above it.
By their numbers in this assay, from the lowest: compounds 2 and 4 (each within the scatter of the next); then compounds 1 and 3 (each within the scatter of the next).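

In this assay, going by these compounds alone, chloro in place of hydrogen on this aromatic carbon gives a 10-fold lower number from compound 3 to compound 4 (1.01 log units; beyond the scatter) and so is the first measured change at this position, a large one. With the chloro present, trifluoromethyl in place of ethyl gives a 1.9-fold higher number from compound 2 to compound 4 (0.27 log units; within the scatter) while trifluoromethyl in place of methyl gives a 6.3-fold lower number from compound 1 to compound 4 (0.80 log units; beyond the scatter) on the saturated chain. Nothing shown here speaks to the reason for these steps. The compounds shown leave open whether fluoro, bromo or methoxy on the same aromatic carbon would give a step like that of chloro.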